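The source may report more compounds than this note shows. Statements on the series, on what has been measured and on what is new or still open speak of the compounds shown alone.

Compound 1 `CC(C)c1ccc(-c2nc(SCc3cn(CC(=O)NC(=O)Nc4ccccn4)nn3)nc(Nc3ccccc3Cl)c2C#N)cc1` is the only one of the two measured compounds with a number: in a functional assay on MCF7 cells (Homo sapiens) for inhibition, read by MTT assay, with a stated time of 72 h (on this read-out higher numbers stand for weaker inhibition and lower numbers for stronger inhibition), compound 1 gives 43700 nM. Compound 2 `Cc1cccc(Nc2nc(SCc3cn(CC(=O)NC(=O)Nc4ccccn4)nn3)nc(-c3ccc(C(C)C)cc3)c2C#N)c1` reaches only the limit of this assay, > 64000 nM, so compound 2 is known just as a floor. Among the measured compounds shown here, the one measured step, an at least 1.4-fold higher number from compound 1 to compound 2 (0.16 log units; that floor lies within the scatter), is a lower bound that lies within the scatter. Compound 3 `CC(C)c1ccc(Nc2nc(SCc3cn(CC(=O)NC(=O)Nc4ccccn4)nn3)nc(-c3ccc(C(C)C)cc3)c2C#N)cc1` differs from compound 2 by 4-isopropylphenyl in place of 3-methylphenyl on a nitrogen on an aromatic ring. For the measured compounds named here, no measured step bears on this change, and the only anchor is the limit of > 64000 nM in this assay, at which 1 of the 2 values shown sits, so compound 3 is expected to stay at or beyond that limit, with a step that the limit leaves unreadable from compound 2 to compound 3. Compound 3 is therefore estimated at 75000 nM, between 30000 nM and 180000 nM.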

Compound 3, half-maximal inhibitory concentration: 28600 nM
Beside the measured number, compound 3's estimate is 2.6-fold (0.42 log units) above it; the measured number lies below the stated range.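

In this assay, among the compounds shown here, the group on the nitrogen on an aromatic ring can now be seen to move the read-out: 4-isopropylphenyl in place of 3-methylphenyl gives an at least 2.2-fold lower number from compound 2 to compound 3 (0.34 log units; beyond the scatter) as the first step here beyond the scatter. Set against 2-chlorophenyl, the same group gives a 1.5-fold lower number from compound 1 to compound 3 (0.18 log units; within the scatter) and so leaves compound 1 and compound 3 unordered. Compound 2 stands only at a limit, which makes its step a floor: the limit of > 64000 nM in this assay, at which 1 of the 3 values shown sits.

On these data alone, whether a longer chain such as 4-butylphenyl would carry the number lower stays open. So does what an amine or a carboxylic acid on this phenyl would do.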